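The compounds below may be only part of what the source reports. "The series", "measured", "known", "first", "only" and "open" are said of these compounds alone.

Measured in a functional assay on T47D cells (Homo sapiens) for inhibition, read by CCK-8 assay, with a stated time of 72 h, tested at 10 uM; a lower number here means less inhibition of growth, a higher number more inhibition of growth at the concentration tested:
compound 1 `CN(C)C(=O)c1cc2cnc(Nc3ccc(NC(=O)C4(C(=O)Nc5ccc(F)cc5)CC4)cc3)nc2n1C1CCCC1`: 105%
compound 2 `CN(C)C(=O)c1cc2cnc(Nc3ccc(NC(=O)C4(C(=O)Nc5cccc(F)c5)CC4)cc3)nc2n1C1CCCC1`: -0.4%
compound 3 `CN(C)C(=O)c1cc2cnc(Nc3ccc(NC(=O)C4(C(=O)Nc5cccc(Cl)c5)CC4)cc3)nc2n1C1CCCC1`: 92.6%

Of these three, compound 3 stands second, with compound 1 above it and compound 2 far below it. The next compound to be tested is compound 4 `Cc1ccc(NC(=O)C2(C(=O)Nc3ccc(Nc4ncc5cc(C(=O)N(C)C)n(C6CCCC6)c5n4)cc3)CC2)cc1`, which differs from compound 3 at one place: 4-methylphenyl in place of 3-chlorophenyl on an amide-type nitrogen. In words, this is 4-methylphenyl in place of 3-chlorophenyl on an amide-type nitrogen.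

Among the measured compounds shown here, all the measured steps concern this same group. Putting 3-fluorophenyl in place of 4-fluorophenyl gave a number 105.4 percentage points lower from compound 1 to compound 2 (beyond the scatter). Putting 3-chlorophenyl in place of 4-fluorophenyl gave only a number 12.4 percentage points lower from compound 1 to compound 3 (beyond the scatter). Chloro in place of fluoro on an aromatic carbon gave a number 93 percentage points higher from compound 2 to compound 3 (beyond the scatter). A small edit here can therefore change very little or nearly everything.

For the measured compounds named here, no measured compound carries a methyl group, so there is no direct precedent. The nearest match to 4-methylphenyl is the 4-fluorophenyl of compound 1, which gives 105%, so growth inhibition should stay high. Still, a collapse like that of compound 2 at -0.4% cannot be excluded, and the range must stay wide.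

The expected change is modest and downward, a number 12.6 percentage points lower from compound 3 to compound 4 (beyond the scatter).

For compound 4 the estimated value is 80%, with an expected range from 15% to 108%.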

Compound 4, percent growth inhibition at one concentration: 99.6%
The estimate for compound 4 lay 19.6 percentage points below the measured number; the range from low to high includes it.
By their numbers in this assay, from the lowest: compound 2; then compounds 3, 4 and 1 (each within the scatter of the next, the first and the last beyond it).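

In this assay, exchanging the fluoro group for a methyl group gives a number 5.4 percentage points lower from compound 1 to compound 4 (within the scatter) and 4-methylphenyl in place of 3-chlorophenyl gives a number 7 percentage points higher from compound 3 to compound 4 (within the scatter) so a phenyl ring carrying only carbon and hydrogen does as well here as the two rings that carry a halogen. Halogen is therefore not required on this amide-type nitrogen's ring for high growth inhibition at the tested concentration. With 4-methylphenyl in place of 3-fluorophenyl giving a number 100 percentage points higher from compound 2 to compound 4 (beyond the scatter) compound 2 is now the only one of the four that falls far below the others, and nothing available explains this drop or the similar numbers of the other three.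

As far as these compounds go, it remains open whether a methoxy group, an ethyl group, an amine or a carboxylic acid on this phenyl ring would keep growth inhibition as high as in compound 4 or lose it as in compound 2. With only compound 2 showing the loss, it is also unclear whether that loss belongs to 3-fluorophenyl alone or would return with other groups on this ring.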